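A few compounds are considered here, and "the series" means these few. Any claim that something is new, unique, unknown or untested is made for them only; others in the source may bear on it.

Working notes on the series, read throughout in an ADME assay on A549 cells (Homo sapiens) for cytotoxicity, read by resazurin assay, with a stated time of 48 h; on this read-out lower numbers stand for higher toxicity in this test and higher numbers for lower toxicity in this test. Compound 1 `O=C(Nc1ccc(NCC2CC2)cc1Cl)c1cc(Cl)ccc1O` gives 14400 nM with cyclopropyl on a saturated chain carbon bound to a nitrogen on an aromatic ring. Compound 2 `O=C(Nc1ccc(NCc2cc(F)cc(Cl)c2)cc1Cl)c1cc(Cl)ccc1O` gives 11100 nM with 3-chloro-5-fluorophenyl at that place. Compound 3 `O=C(Nc1ccc(NCc2ccncc2)cc1Cl)c1cc(Cl)ccc1O` gives 65300 nM with pyridin-4-yl there, the highest of the three numbers and beyond the scatter of both others.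

Compound 4 `O=C(Nc1ccc(NCc2ccc3cn[nH]c3c2)cc1Cl)c1cc(Cl)ccc1O` is next, and 1H-indazol-6-yl in place of pyridin-4-yl on a saturated chain carbon bound to a nitrogen on an aromatic ring is its change from compound 3. For the measured compounds named here, three measured steps bear on it, all at the same place. Pyridin-4-yl in place of cyclopropyl gives a 4.5-fold higher number from compound 1 to compound 3 (0.66 log units; beyond the scatter) as a modest step, and pyridin-4-yl in place of 3-chloro-5-fluorophenyl gives a 5.9-fold higher number from compound 2 to compound 3 (0.77 log units; beyond the scatter) as another. 3-chloro-5-fluorophenyl in place of cyclopropyl gives a 1.3-fold lower number from compound 1 to compound 2 (0.11 log units; within the scatter) as the smallest of the three.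

The entering group holds a six-membered aromatic ring of carbon only, and compound 2 with such a ring gives 11100 nM as the nearest guide. A modest step to a lower number is expected in this assay on that likeness alone. Going by the values given here, no measured compound holds a five-membered aromatic ring with 2 hetero atoms, and the range stays wide. The estimated step is a 3.3-fold lower number from compound 3 to compound 4 (0.51 log units; beyond the scatter) as a working figure. For compound 4 the expected value is 20000 nM within an estimated range of 8000 nM to 50000 nM for now.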

Compound 4, half-maximal cytotoxic concentration: 45300 nM
Compound 4: the middle estimate sits 2.3-fold (0.36 log units) below what was measured; the measured number falls inside the stated range.
By their numbers in this assay, from the lowest: compounds 2 and 1 (each within the scatter of the next); then compounds 4 and 3 (each within the scatter of the next).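

In this assay, 1H-indazol-6-yl in place of pyridin-4-yl gives a 1.4-fold lower number from compound 3 to compound 4 (0.16 log units; within the scatter), so a six-membered aromatic ring of carbon only within the entering group does not by itself bring the number down to that of compound 2. Set against the other two groups at this place, on a saturated chain carbon bound to a nitrogen on an aromatic ring, 1H-indazol-6-yl gives a 4.1-fold higher number from compound 2 to compound 4 (0.61 log units; beyond the scatter) and a 3.1-fold higher number from compound 1 to compound 4 (0.50 log units; beyond the scatter), which leaves the two groups with nitrogen in an aromatic ring together at the high end and cyclopropyl and 3-chloro-5-fluorophenyl together at the low end, with none of these four compounds going against that split. Nothing measured here bears on the cause of this split.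

The compounds shown leave open whether the split follows the ring nitrogen at all, since an unsubstituted phenyl group at this place would separate that nitrogen from the chlorine and fluorine carried by compound 2. They also leave open whether a saturated amine such as piperidin-4-yl, or a carboxylic acid, would fall with the high pair or the low pair.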